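Swapping the Sulfonyl Ring and Expected Cell Toxicity

The source may hold more compounds than are shown below. What is called first, only, known or untested is meant among the compounds shown, and "the series" means these compounds.

Measured compounds:
- compound 1 `O=S(=O)(Nc1ccc2oc(-c3ccccc3)nc2c1)c1cccs1`: in an ADME assay on HEK293 cells (Homo sapiens) for cytotoxicity, read by resazurin assay, with a stated time of 48 h (on this read-out lower numbers stand for higher toxicity in this test and higher numbers for lower toxicity in this test), compound 1 gives 97000 nM
- compound 2 `O=S(=O)(Nc1ccc(-c2nc3ccccc3o2)cc1)c1ccccc1Cl`: in this assay compound 2 reaches > 100000 nM, which is a limit of the test rather than a number

For the measured compounds named here, compound 1 holds the only actual number in this set, and it sits close to the limit of > 100000 nM in this assay, at which 1 of the 2 values shown sits. Compound 2 gives only that limit, so the two compounds cannot be set apart with confidence; both are weakly toxic to these cells at best.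

Compound 3 `COc1ccc(S(=O)(=O)Nc2ccc3oc(-c4ccccc4)nc3c2)cc1` has not yet been measured. Relative to compound 1 it carries one change: 4-methoxyphenyl in place of thiophen-2-yl on a sulfonyl sulfur. The sulfonamide linkage and the shared core of compound 1 stay in place.

Going by the values given here, with only one number and one limit on hand, no step between measured compounds can guide the expectation. A small step is expected, likely not beyond the usual scatter, with the step of a 1.0-fold higher number from compound 1 to compound 3 (0.01 log units; within the scatter) pointing, if anywhere, toward somewhat lower toxicity. Compound 3 is therefore expected to give about 100000 nM in this assay, within a range of 40000 nM to 250000 nM, and may well return only a limit.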

Compound 3, half-maximal cytotoxic concentration: 91000 nM
Beside the measured number, compound 3's estimate is 1.1-fold (0.04 log units) above it; the measured number falls inside the stated range.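

For the compounds shown here, this swap gives the first real comparison on a sulfonyl sulfur in this assay, and the step is a 1.1-fold lower number from compound 1 to compound 3 (0.03 log units; within the scatter), so compound 1 and compound 3 cannot be told apart. Replacing thiophen-2-yl, a five-membered aromatic ring with 1 hetero atom, by 4-methoxyphenyl, a six-membered aromatic ring of carbon only with 8 heavy atoms in the group, therefore leaves the read-out within the normal variation between repeat measurements, and both compounds remain only weakly toxic to these cells. This flat result comes from the very top of the range the test can read, and compound 2 stands at a limit of the test rather than at a number: the limit of > 100000 nM in this assay, at which 1 of the 3 values shown sits.

Both groups compared here are aromatic rings with no net charge, so the result cannot say whether a charged group on a sulfonyl sulfur would behave the same way. A phenyl ring bearing a carboxylic acid or an amine in place of 4-methoxyphenyl would test that question, and the compounds shown leave open whether any group here can bring the number clearly down.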